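A few compounds are considered here, and "the series" means these few. Any claim that something is new, unique, unknown or untested is made for them only; others in the source may bear on it.

Measured compounds in an assay on HeLa cells for displacement of a labelled ligand from adenosine receptor A3 (Homo sapiens), read by scintillation counting, with a stated time of 180 min, tested at 10 uM; a lower number here means less inhibition, a higher number more inhibition at the concentration tested (going by the name of the read-out):
- compound 1 `N=c1oc2ccc(Br)cc2cc1C(=O)NCC(O)CO`: 10%
- compound 2 `N=c1oc2ccc(Br)cc2cc1C(=O)NCCO`: 0%
- compound 3 `COc1cccc2cc(C(=O)NCCO)c(=N)oc12`: 23%

Compound 2 stands lowest of the three numbers shown. Its nearest neighbour is compound 1, whose value lies within the scatter of it; compound 3 lies furthest, beyond the scatter and higher. Going by the values given here, the one step measured so far, a number 10 percentage points lower from compound 1 to compound 2 (within the scatter), was within the scatter, so removing a hydroxymethyl from the chain on the amide-type nitrogen changed little.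

Compound 4 `N=c1oc2ccc(Br)cc2cc1C(=O)NC1CCCCC1` is not yet measured. It differs from compound 2 by cyclohexyl in place of 2-hydroxyethyl on an amide-type nitrogen. Among the compounds with values here, no measured step bears directly on this change: the step from compound 1 to compound 2 only shortened the chain, whereas here the whole 2-hydroxyethyl is replaced by cyclohexyl. With the amide-type nitrogen substituent so far only moving the number within the scatter, the expectation for compound 4 is a step of a number 12 percentage points higher from compound 2 to compound 4 (beyond the scatter) that stays near the low end of the series, with wide uncertainty. The estimated value for compound 4 in this assay is 12%, in the range 0% to 35%.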

Compound 4, a percentage reported as inhibition, at one concentration (the size of the read-out at that concentration, not a potency): 8%
For compound 4 the middle estimate is 4 percentage points above the measured one; the measured number falls inside the stated range.
By their numbers in this assay, from the lowest: compounds 2, 4 and 1 (each within the scatter of the next); then compound 3.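

In this assay the new result gives two readings at the amide-type nitrogen: a number 8 percentage points higher from compound 2 to compound 4 (within the scatter) for cyclohexyl in place of 2-hydroxyethyl, and a number 2 percentage points lower from compound 1 to compound 4 (within the scatter) for cyclohexyl in place of 2,3-dihydroxypropyl. On this core, then, a six-membered carbon ring with no hydrogen-bond donor or acceptor reads the same as both hydroxylated chains, and the hydroxyl groups of those chains are not required to keep the number where it stands. No evidence is available on why this substituent change leaves the number so little moved.

As far as these compounds go, whether an amine, a carboxylic acid or a phenyl ring at this nitrogen would move the number remains open. So does whether cyclohexyl would behave the same on the methoxy-bearing core of compound 3, which gives 23% with 2-hydroxyethyl.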